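The source may report more compounds than this note shows. Statements on the series, on what has been measured and on what is new or still open speak of the compounds shown alone.

In a functional assay on PC-3 cells (Homo sapiens) for antiproliferative activity, read by MTT assay, with a stated time of 72 h (a higher number here means a weaker inhibitor, a lower number a stronger inhibitor), compound 1 `CCN(CC)CCNC(=O)c1ccc(C(CC)(CC)c2ccc(OCC(O)C(C)(C)C)c(C)c2)n1CC` gives 2800 nM. Compound 2 `CCn1c(C(=O)NCc2ccc(OC)cc2)ccc1C(CC)(CC)c1ccc(C#CC(O)(CC)CC)c(C)c1` is recorded as > 50000 nM, which is a limit of the assay and not a number. Compound 3 `CCn1c(C(=O)On2nnc3ccccc32)ccc1C(CC)(CC)c1ccc(C#CC(O)(CC)CC)c(C)c1` keeps the rest of compound 2 and changes one part: a group of 10 heavy atoms (6 carbon, 3 nitrogen, 1 oxygen; one five-membered aromatic ring with 3 hetero atoms, one six-membered aromatic ring of carbon only) in place of a group of 10 heavy atoms (8 carbon, 1 nitrogen, 1 oxygen; one six-membered aromatic ring of carbon only), on a carbonyl carbon. Among the compounds with values here, no measured pair shows what such a swap does, and the starting point is only a limit, so the expectation is loose: a modest gain in potency, or no measurable change. The expected size of the change is an at least 1.6-fold lower number from compound 2 to compound 3 (0.22 log units; that floor lies within the scatter). For compound 3, the estimated value is 30000 nM, with an expected range of 8000 nM to 60000 nM.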

Compound 3, half-maximal inhibitory concentration: > 50000 nM
Compound 3 was reported as a limit; the forecaster's own chance of this, stated with the estimate: 50%; middle value at least 1.6-fold (0.22 log units) away from the limit.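

Within the data shown here, compound 2 and compound 3 are each recorded only as a limit, so no step between them can be read: the limit of > 50000 nM in this assay, at which 2 of the 3 values shown sit. As far as these compounds go, how strong either compound truly is, and whether this swap on the carbonyl carbon changes that, stays open.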